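The source may hold more compounds than are shown below. What is called first, only, known or untested is meant among the compounds shown, and "the series" means these compounds.

Measured so far in a functional assay on MGC-803 cells (Homo sapiens) for inhibition, read by MTT assay, with a stated time of 48 h; on this read-out lower numbers stand for stronger inhibition and higher numbers for weaker inhibition:
- compound 1, `C=C(C)C(=O)N(Cc1ccc(OC)c(O)c1)c1cc(OC)c(OC)c(OC)c1`: 390 nM
- compound 2, `C/C=C/C(=O)N(Cc1ccc(OC)c(Cl)c1)c1cc(OC)c(OC)c(OC)c1`: 7100 nM
- compound 3, `COc1cc(NCc2ccc(Br)cc2)cc(OC)c1OC`: > 80000 nM

Compound 1 holds the lowest of the two numbers reported in this assay. Compound 2 stands well above it, a gap beyond the usual scatter of repeated measurements. Compound 3 returns only (the limit of > 80000 nM in this assay, at which 1 of the 3 values shown sits), a limit of the assay rather than a number, so it gives no point for comparison.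

Among the measured compounds shown here, no pair of measured compounds differs in a single place, so no measured step exists against which the next change can be sized.

Compound 4, `C=CC(=O)N(Cc1ccc(OC)c(O)c1)c1cc(OC)c(OC)c(OC)c1`, has not yet been measured in this assay. It differs from compound 1 in one place only: hydrogen in place of methyl on a double-bonded chain carbon bound to a carbonyl carbon. Hydrogen in place of methyl on a double-bonded chain carbon bound to a carbonyl carbon is a small change in mass, and nothing among the measured compounds speaks to it directly.

The expectation therefore rests on compound 1 alone. The change is expected to move the number little, if anything toward a lower value, and to stay within the scatter. Compound 4 is expected at 250 nM, in the range 60 nM to 1000 nM. The expected step is a 1.6-fold lower number from compound 1 to compound 4 (0.19 log units; within the scatter).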

Compound 4, half-maximal inhibitory concentration: 62 nM
Estimate against measurement, compound 4: 4.0-fold (0.61 log units) above; low and high end bracket the measured number.
By their numbers in this assay, from the lowest: compound 4; then compound 1; then compound 2. At a limit, above all of these: compound 3.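

Notes on the chain carbon: in this assay, hydrogen in place of methyl on a double-bonded chain carbon bound to a carbonyl carbon gives a 6.3-fold lower number from compound 1 to compound 4 (0.80 log units; beyond the scatter), so the methyl of compound 1 is not needed at this place for a low number. Among the compounds shown here, this is the first single-place step, and it shows that the number responds to this position: the loss of 1 heavy atom, 1-methylethenyl to vinyl, is enough to carry the step past the usual scatter. Nothing at hand accounts for the size or direction of this step.

Going by these compounds, only hydrogen and methyl have been compared at this carbon, so it remains open how an ethyl group, a longer chain, a chloromethyl group or an amine-bearing chain would read there. On these data alone, compound 2 differs from compound 1 in more than one place and cannot settle the matter, so it also remains open whether the same exchange would give a step of similar size with a group other than the hydroxy of compounds 1 and 4 on the benzyl ring.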